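A few compounds are considered here, and "the series" means these few. Any claim that something is new, unique, unknown or untested is made for them only; others in the source may bear on it.

Series of three measured compounds: compound 1 `O=c1c(OCc2cccc([N+](=O)[O-])c2)c(-c2ccccc2)oc2cc(O)cc(O)c12`, compound 2 `Cc1cccc(COc2c(-c3ccccc3)oc3cc(O)cc(O)c3c2=O)c1` and compound 3 `O=c1c(OCc2ccc(Cl)cc2)c(-c2ccccc2)oc2cc(O)cc(O)c12`. In an ADME assay on Huh-5-2 cells (Homo sapiens) for cytotoxicity, read by WST assay, with a stated time of 3 days (a higher number here means that more compound is tolerated, a lower number that less compound is tolerated), compound 1 gives 31000 nM, compound 2 gives 29000 nM and compound 3 gives 36000 nM. Compound 3 carries the top number of the three, yet the steps of a 1.2-fold higher number from compound 1 to compound 3 (0.06 log units; within the scatter) and a 1.2-fold higher number from compound 2 to compound 3 (0.09 log units; within the scatter) both sit within the scatter, as does a 1.1-fold lower number from compound 1 to compound 2 (0.03 log units; within the scatter); the three compounds are not separated. Compound 4 `O=c1c(OCc2ccc(Br)cc2)c(-c2ccccc2)oc2cc(O)cc(O)c12` is unmeasured; the change from compound 3 is bromo in place of chloro on an aromatic carbon. For the measured compounds named here, no measured step swaps one halogen for another; the nearest comparisons are the exchanges of the benzyl substituent, all within the scatter. The step of no change at the digits printed from compound 3 to compound 4 (within the scatter) is therefore expected to stay within the scatter, with no direction. Compound 4 is estimated at 36000 nM, range 18000 nM to 72000 nM.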

Compound 4, half-maximal cytotoxic concentration: 2000 nM
The estimate for compound 4 lay 18-fold (1.26 log units) above the measured number, and the stated range ends above it.
By their numbers in this assay, from the lowest: compound 4; then compounds 2, 1 and 3 (each within the scatter of the next).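

In this assay, the position para to a large group responds strongly to a single-atom halogen exchange, bromo in place of chloro (an 18-fold lower number from compound 3 to compound 4 (1.26 log units; beyond the scatter)), whereas the earlier benzyl exchanges all stayed within the scatter. Compound 4 also stands apart from the other two compounds (a 15-fold lower number from compound 2 to compound 4 (1.16 log units; beyond the scatter); a 16-fold lower number from compound 1 to compound 4 (1.19 log units; beyond the scatter)), so the 4-bromobenzyl group alone separates within this series. Nothing measured here explains this result.

Going by these compounds, whether the fall is particular to bromo remains open. Iodo, fluoro or methoxy at this position would show whether other groups give a similar result.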